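Dropping One Methoxy Group from a Promising Analogue

The source may hold more compounds than are shown below. What is called first, only, known or untested is meant among the compounds shown, and "the series" means these compounds.

Two compounds built on a shared core have so far been examined in a functional assay on the whole organism (strain Swiss albino) with Mus musculus as the target, with a stated time of 4 h; on this read-out lower numbers stand for an effect already at smaller amounts and higher numbers for an effect only at larger amounts of compound. Compound 1 `O=C(N/N=C/c1ccc(Cl)cc1Cl)Nc1cccc2ccccc12` gives 300 mg/kg in this assay. Compound 2 `COc1cc(/C=N/NC(=O)Nc2cccc3ccccc23)cc(OC)c1OC` gives 100 mg/kg, the lowest number of the two, and its gap to compound 1 lies beyond the usual scatter of this assay. Compound 3 `COc1ccc(/C=N/NC(=O)Nc2cccc3ccccc23)cc1OC` is the next candidate and differs from compound 2 in a single place: hydrogen in place of methoxy on an aromatic carbon. Going by the values given here, no measured pair shows this same change, so its effect cannot be read off from existing numbers and must be expected from the structures alone. Because compound 2 gives 100 mg/kg and only a small group is removed, the step from this change is expected to be modest, namely a 1.5-fold higher number from compound 2 to compound 3 (0.18 log units; within the scatter), if anything toward a slightly higher number. Compound 3 is therefore estimated at 150 mg/kg, with a range from 75 mg/kg to 300 mg/kg.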

Compound 3, minimum effective dose: 300 mg/kg
Beside the measured number, compound 3's estimate is 2.0-fold (0.30 log units) below it; measured number inside the range.
By their numbers in this assay, from the lowest: compound 2; then compounds 1 and 3 (each within the scatter of the next).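

In this assay, going by these compounds alone, this is the first direct reading of this position: hydrogen in place of methoxy on this aromatic carbon, ortho to a methoxy group and meta to a large group, gives a 3.0-fold higher number from compound 2 to compound 3 (0.48 log units; beyond the scatter). Nothing else differs between the two structures, so the methoxy group at this place clearly counts in the read-out, and a larger amount of compound is needed once it is gone. No measurement at hand accounts for this rise in the number.

From the compounds shown here alone, it stays open whether a methoxy group is specifically required on this carbon, or whether a hydroxyl group, an amine or a longer chain such as ethoxy would keep the lower number of compound 2. Going by these compounds, this pair also speaks for one place only, so what removing either of the other methoxy groups would do remains unknown.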